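Ester to Alcohol at the Chain End of a Silyl-Protected Pyran

This account rests on a few compounds, and the source may have more. Where it says the series, first, only, none or still open, it means among the compounds named here.

Of the compounds shown here, two from this series have been tested in a functional assay on MCF7S cells (Homo sapiens) for inhibition; a higher number here means a weaker inhibitor of growth, a lower number a stronger inhibitor of growth. Compound 1 `CC(C)(C)[Si](C)(C)O[C@H]1CCCO[C@@H]1CC=O` gives 82000 nM, and compound 2 `COC(=O)/C=C/C[C@H]1OCCC[C@@H]1O[Si](C)(C)C(C)(C)C` gives 48000 nM. For the measured compounds named here, the only measured step, a 1.7-fold lower number from compound 1 to compound 2 (0.23 log units; within the scatter), replaces the formyl group with a 2-(methoxycarbonyl)ethenyl group; it lies within the scatter, so compound 2 and compound 1 stand on a par in this assay, and compound 2 has no margin over compound 1 that can be called real.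

Compound 3 `CC(C)(C)[Si](C)(C)O[C@H]1CCCO[C@@H]1C/C=C/CO` differs from compound 2 by hydroxymethyl in place of methoxycarbonyl on a double-bonded chain carbon bound to a double-bonded chain carbon. Going by the values given here, no measured pair shows the consequence of this particular exchange. Among the compounds with values here, the one step that exists, a 1.7-fold lower number from compound 1 to compound 2 (0.23 log units; within the scatter), shows that altering the end of the side chain left this assay essentially unmoved, and that is the only guidance available. On that basis, the step from compound 2 to compound 3 is expected to be a 1.0-fold higher number from compound 2 to compound 3 (0.02 log units; within the scatter), that is, no movement beyond the scatter in either direction. For compound 3 the estimate in this assay is therefore 50000 nM, with a plausible range from 20000 nM to 125000 nM.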

Compound 3, concentration for total growth inhibition: 83000 nM
The estimate for compound 3 lay 1.7-fold (0.22 log units) below the measured number; measured number inside the range.
By their numbers in this assay, from the lowest: compounds 2, 1 and 3 (each within the scatter of the next).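

In this assay, the exchange of methoxycarbonyl for hydroxymethyl on a double-bonded chain carbon bound to a double-bonded chain carbon gives a 1.7-fold higher number from compound 2 to compound 3 (0.24 log units; within the scatter) and so shows that this position accepts a group with 1 hydrogen-bond donor in place of one with 0 hydrogen-bond donors without a change that can be called real. The wider comparison, 3-hydroxyprop-1-en-1-yl in place of formyl on a saturated chain carbon bound to a saturated ring carbon, gives a 1.0-fold higher number from compound 1 to compound 3 (0.01 log units; within the scatter) and adds that the formyl, ester and alcohol chain ends of compound 1, compound 2 and compound 3 cannot be told apart in this assay. The data offer no measured reason for this lack of separation.

Whether the insensitivity extends to a chain ending in a carboxylic acid or an amine remains open, since all three ends shown are neutral and none carries a charge. Also open, on these data alone, is whether a longer chain, or any change to the shared core rather than the chain end, would move the number beyond the scatter.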